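Swapping the indole of compound 1 for a bromophenyl

The compounds below may be only part of what the source reports. "The series", "measured", "known", "first", "only" and "open" are said of these compounds alone.

Two compounds have been run through a functional assay on DU-145 cells (Homo sapiens) for inhibition, read by trypan blue exclusion, with a stated time of 96 h; on this read-out higher numbers stand for weaker inhibition of growth and lower numbers for stronger inhibition of growth. Compound 1 `Cc1ccc(CS/C(=C/c2c[nH]c3ccc(Cl)cc23)C(=O)c2ccc(Cl)cc2)cc1` gives 1000 nM in this assay. Compound 2 `O=C(/C(=C\c1ccc(Oc2ccccc2)cc1)Sc1ccc(Br)cc1)c1ccc(Br)cc1` gives 50000 nM in this assay. Compound 1 therefore has the lower of the two numbers, and the gap separating it from compound 2 lies well beyond the usual scatter of repeated measurements. Compound 2 differs from compound 1 in several places at once, so no single structural cause can be read from those two values.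

Compound 3 `Cc1ccc(CS/C(=C/c2ccccc2Br)C(=O)c2ccc(Cl)cc2)cc1` is a closer relative of compound 1. It differs in one place: 2-bromophenyl in place of 5-chloro-1H-indol-3-yl on a double-bonded chain carbon bound to a double-bonded chain carbon. Among the measured compounds shown here, no measured pair shows this change. Because compound 1 gives 1000 nM in this assay with the indole present, the step of a 10-fold higher number from compound 1 to compound 3 (1.00 log units; beyond the scatter) is expected to weaken growth inhibition, by more than the scatter. Compound 3 is estimated to give 10000 nM in this assay, within a range from 2000 nM to 50000 nM.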

Compound 3, concentration for 50% growth inhibition: 10000 nM
Estimate against measurement, compound 3: no gap at the digits printed, and the stated range covers the measured number.
By their numbers in this assay, from the lowest: compound 1; then compound 3; then compound 2.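

In this assay, among the compounds shown here, replacing 5-chloro-1H-indol-3-yl with 2-bromophenyl on a double-bonded chain carbon bound to a double-bonded chain carbon brings a 10-fold higher number from compound 1 to compound 3 (1.00 log units; beyond the scatter) and gives the first single-place reading of this position. Growth inhibition weakens with this change, so the group held at this position affects the result. The swap removes a five-membered aromatic ring and a hydrogen-bond donor and replaces chlorine with bromine, yet nothing here separates these differences or gives a reason for the step.

On these data alone, it remains open whether the loss follows from the missing five-membered ring, the missing donor or the change of halogen. It is also unknown how a phenyl ring carrying an amine in place of the bromine would compare with compound 1 and compound 3.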